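Adding one methoxy to the core of compound 3

The compounds below may be only part of what the source reports. "The series", "measured", "known", "first", "only" and "open" are said of these compounds alone.

In a functional assay on HeLa cells (Homo sapiens) for antiproliferative activity, read by sulforhodamine B assay, with a stated time of 48 h (on this read-out lower numbers stand for stronger inhibition and higher numbers for weaker inhibition), three compounds have been measured:
Compound 1 `COc1ccc(C(=O)/C=C\Nc2ccc(-c3nc4cc(OC)c(OC)c(OC)c4s3)cc2C)cc1O` gives 11400 nM
Compound 2 `COc1ccc(C(=O)/C=C\Nc2ccc(-c3nc4cc(OC)c(OC)c(OC)c4s3)cc2C)cc1F` gives 1200 nM
Compound 3 `COc1cc(OC)c2sc(-c3ccc(N/C=C\C(=O)c4cc(OC)c(OC)c(OC)c4)c(C)c3)nc2c1` gives 16400 nM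

Compound 3 lies within the scatter of compound 1, while compound 2 has a lower number, beyond the scatter. Compound 4 `COc1cc(C(=O)/C=C\Nc2ccc(-c3nc4cc(OC)c(OC)c(OC)c4s3)cc2C)cc(OC)c1OC` differs from compound 3 by methoxy in place of hydrogen on an aromatic carbon. For the measured compounds named here, no measured step covers this change. The only one, a 9.5-fold lower number from compound 1 to compound 2 (0.98 log units; beyond the scatter), lies elsewhere in the molecule, so it shows only that a single replacement can matter here. Compound 1 (11400 nM) and compound 2 (1200 nM) share the core of compound 4, which suggests a small fall at most in this assay. The expected change is a 1.8-fold lower number from compound 3 to compound 4 (0.26 log units; within the scatter), an estimate only. Compound 4 is estimated at 9000 nM (expected range 2000 nM to 30000 nM).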

Compound 4, half-maximal inhibitory concentration: 11100 nM
For compound 4 the middle estimate is 1.2-fold (0.09 log units) below the measured one; low and high end bracket the measured number.
By their numbers in this assay, from the lowest: compound 2; then compounds 4, 1 and 3 (each within the scatter of the next).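

In this assay, for the compounds shown here, methoxy in place of hydrogen on this aromatic carbon, ortho to two methoxy groups, gives a 1.5-fold lower number from compound 3 to compound 4 (0.17 log units; within the scatter), so the one step measured at this position stays within the scatter. With the shared core held, 3,4,5-trimethoxyphenyl in place of 3-fluoro-4-methoxyphenyl on the carbonyl carbon gives a 9.3-fold higher number from compound 2 to compound 4 (0.97 log units; beyond the scatter), whereas in place of 3-hydroxy-4-methoxyphenyl it gives a 1.0-fold lower number from compound 1 to compound 4 (0.01 log units; within the scatter). Nothing available explains these outcomes. From the compounds shown here alone, whether an amine or a chlorine at this position would match methoxy remains open.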